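Removing a Cyclohexyl Group and Vero Cell Toxicity

The source may report more compounds than this note shows. Statements on the series, on what has been measured and on what is new or still open speak of the compounds shown alone.

Of the compounds shown here, three built on a shared core have been tested in an ADME assay on Vero cells (Chlorocebus sabaeus) for cytotoxicity, read by MTT assay, with a stated time of 96 h; on this read-out higher numbers stand for lower toxicity in this test and lower numbers for higher toxicity in this test. Compound 2 `CC(=O)c1ccc2c(c1)nc(-c1ccc(C(F)(F)F)cc1)n2C1CCCCC1` gives 35000 nM. Compound 1 `CC(=O)c1ccc2[nH]c(-c3ccc(C(F)(F)F)cc3)nc2c1` gives only a limit of the test, > 100000 nM. That limit is the one marked by the limit of > 100000 nM in this assay, at which 1 of the 3 values shown sits. The change between these two is hydrogen in place of cyclohexyl on an aromatic nitrogen, and in this assay it brings an at least 2.8-fold higher number from compound 2 to compound 1 (0.45 log units; beyond the scatter). Compound 3 `CC(=O)c1ccc2c(c1)nc(-c1ccoc1)n2C1CCCCC1` carries a different group on the shared core; how its core differs from that of compound 2 is not broken down here. In this assay compound 3 gives 80000 nM. The unmeasured compound 4 `CC(=O)c1ccc2[nH]c(-c3ccoc3)nc2c1` is made from compound 3 by hydrogen in place of cyclohexyl on an aromatic nitrogen. Going by the values given here, this is the same kind of change as the one from compound 2 to compound 1, though here the ring nitrogen sits next to the ring atom that bears a furan-3-yl group rather than a large group. Because the earlier step gave an at least 2.8-fold higher number from compound 2 to compound 1 (0.45 log units; beyond the scatter), compound 4 is expected to show a 2.5-fold higher number from compound 3 to compound 4 (0.40 log units; beyond the scatter). Compound 4 is therefore estimated at 200000 nM, between 80000 nM and 500000 nM, and may well come out as a limit of the test again.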

Compound 4, half-maximal cytotoxic concentration: > 100000 nM
Compound 4: a limit, no number (the forecaster's own chance of this, stated with the estimate: 70%); the middle value lies beyond the limit too.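

In this assay, putting hydrogen in place of cyclohexyl on the aromatic nitrogen gives an at least 1.2-fold higher number from compound 3 to compound 4 (0.09 log units; that floor lies within the scatter). Compound 4 gives > 100000 nM, which is a limit of the test and not a number, so this step is only a floor on the true change. On both cores the change leads to a limit reading with no sign of a lower number, but the second step alone is not shown to exceed the scatter, and nothing shows that the change has the same size on each core: the same change on two cores in this assay, an at least 2.8-fold higher number (0.45 log units; beyond the scatter) from compound 2 to compound 1 and an at least 1.2-fold higher number (0.09 log units; that floor lies within the scatter) from compound 3 to compound 4; the limit leaves it open whether they differ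

As far as these compounds go, compound 1 and compound 4 cannot be ranked against each other, since neither has a number of its own: the limit of > 100000 nM in this assay, at which 2 of the 4 values shown sit. Also open is what other groups on that aromatic nitrogen would give, such as a methyl group, a longer chain or an amine-bearing chain, and whether any of them would bring a reading that can be compared across both cores.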